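Swapping methyl for trifluoromethoxy on a shared core

This account rests on a few compounds, and the source may have more. Where it says the series, first, only, none or still open, it means among the compounds named here.

Compound 1 `CCNC(=O)c1cc(Oc2ccc(NC(=O)c3nn(-c4ccccc4OC(F)(F)F)c(=O)cc3C)cc2)ccn1` and compound 2 `CCNC(=O)c1cc(Oc2ccc(NC(=O)c3nn(-c4ccccc4C)c(=O)cc3C)cc2)ccn1` share a core and differ in one group. In a functional assay on HeLa cells (Homo sapiens) for antiproliferative activity, read by MTT assay, with a stated time of 72 h (a lower number here means a stronger inhibitor, a higher number a weaker inhibitor), compound 1 gives 3990 nM, while compound 2 gives 27300 nM. The change trifluoromethoxy in place of methyl on an aromatic carbon gives a 6.8-fold lower number from compound 2 to compound 1 (0.84 log units; beyond the scatter). Compound 3 `CCCNC(=O)c1cc(Oc2ccc(NC(=O)c3nn(-c4ccccc4C)c(=O)cc3C)cc2F)ccn1` gives 24600 nM in this assay; the difference between the core of compound 3 and the core of compound 2 is not broken down here. Compound 4 `CCCNC(=O)c1cc(Oc2ccc(NC(=O)c3nn(-c4ccccc4OC(F)(F)F)c(=O)cc3C)cc2F)ccn1` is not yet measured. It differs from compound 3 by trifluoromethoxy in place of methyl on an aromatic carbon, the same change as that from compound 2 to compound 1, at the same place. Among the compounds with values here, because the earlier step was a 6.8-fold lower number from compound 2 to compound 1 (0.84 log units; beyond the scatter), a step of similar size is expected, a 5.5-fold lower number from compound 3 to compound 4 (0.74 log units; beyond the scatter), with some uncertainty since only one such pair is known. Compound 4 is therefore estimated at 4500 nM, between 1500 nM and 13000 nM.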

Compound 4, half-maximal inhibitory concentration: 3690 nM
Estimate against measurement, compound 4: 1.2-fold (0.09 log units) above, within the range that was stated.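

In this assay, putting 2-(trifluoromethoxy)phenyl in place of 2-methylphenyl gives a 6.7-fold lower number from compound 3 to compound 4 (0.82 log units; beyond the scatter). The same change has now been seen on two cores, and the size of the step carries over from one to the other: the same change on two cores in this assay, a 6.8-fold lower number (0.84 log units; beyond the scatter) from compound 2 to compound 1 and a 6.7-fold lower number (0.82 log units; beyond the scatter) from compound 3 to compound 4, 1.0-fold (0.01 log units) apart, within the scatter of two such steps. Within the data shown here, this is only one pair on each of two cores in a single assay, so it does not show that the step would hold on other cores, and it does not explain why the number falls.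

Going by these compounds, it remains open whether a methoxy group or a chlorine atom at this place would give a similar step. On these data alone, it is also open whether the step would survive a longer chain on the amide.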